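Compound 2 to compound 3: a limit as starting point

The compounds below may be only part of what the source reports. "The series", "measured", "known", "first", "only" and "open" are said of these compounds alone.

Measured in an ADME assay on cells (Fibroblast, Gallus gallus) for cytotoxicity, read by CCK-8 assay, with a stated time of 48 h; a higher number here means that more compound is tolerated, a lower number that less compound is tolerated:
Compound 1 `CCC(CC)O[C@@H]1C=C(C(=O)O)C[C@H](NCc2ccc(C(C)(C)C)cc2)[C@H]1NC(C)=O` gives > 200000 nM, a limit.
Compound 2 `CCC(CC)Oc1ccc(CN[C@H]2CC(C(=O)O)=C[C@@H](OC(CC)CC)[C@@H]2NC(C)=O)cc1` gives > 200000 nM, a limit.

For the measured compounds named here, compound 2 stands only at a limit, > 200000 nM, and the one other value shown is a limit too. What the data offer so far is the limit of > 200000 nM in this assay, at which 2 of the 2 values shown sit.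

Compound 3 `CCC(CC)O[C@@H]1C=C(C(=O)O)C[C@H](NCc2ccc(SCC(C)C)cc2)[C@H]1NC(C)=O` is not yet measured. It differs from compound 2 as follows: isobutylsulfanyl in place of (pentan-3-yl)oxy on an aromatic carbon. In words, it carries isobutylsulfanyl in place of (pentan-3-yl)oxy on an aromatic carbon, para to a large group.

Going by the values given here, the one measured step at this place is a step that the two limits leave unreadable from compound 1 to compound 2, with (pentan-3-yl)oxy in place of tert-butyl. It has no readable size to carry over, so it points in no direction. The expectation therefore rests on compound 2 with its limit of > 200000 nM.

In this assay the expected step that the limit leaves unreadable from compound 2 to compound 3 is none beyond the scatter, and another limit is the likeliest report. The estimate for compound 3 is 250000 nM, with an expected range from 120000 nM to 500000 nM.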

Compound 3, half-maximal cytotoxic concentration: > 200000 nM
Compound 3: only a limit was reported; the forecaster's own chance of this, stated with the estimate: 85%; the middle value lies beyond the limit too.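

In this assay compound 3 gives > 200000 nM, which is a limit. The steps to compound 3 from compound 1 and from compound 2 therefore cannot be read. The compounds shown leave open how far compound 1, compound 2 and compound 3 differ, and whether any group at this aromatic carbon would give a readable value, as the data still offer only this: the limit of > 200000 nM in this assay, at which 3 of the 3 values shown sit.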